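From Butyl to Methyl on a Shared Core

The compounds below may be only part of what the source reports. "The series", "measured", "known", "first", "only" and "open" are said of these compounds alone.

Compound 1 `CC(C)N1C(=O)NC2(CC2c2ccc3cccc(OCc4ccccc4)c3n2)C1=O`: 300 mg/kg
Compound 2 `CCC(CO)N1C(=O)NC2(CC2c2ccc3cccc(OCc4ccccc4)c3n2)C1=O`: 30 mg/kg
Compound 3 `CCCCN1C(=O)NC2(CC2c2ccc3cccc(OCc4ccccc4)c3n2)C1=O`: 300 mg/kg

Three compounds share one core and differ only in the group on the amide-type nitrogen in the ring. All were tested in a functional assay on the whole organism (strain Kunming) with Mus musculus as the target, in the maximal electroshock model, with a stated time of 0.5 h; a higher number here means that more compound is needed for the effect, a lower number that less compound is needed. Among the measured compounds shown here, compound 3 stands level with compound 1, and together they are the highest of the three numbers; the one step beyond the scatter is a 10-fold higher number from compound 2 to compound 3 (1.00 log units; beyond the scatter), while no change at the digits printed from compound 1 to compound 3 (within the scatter) shows that swapping one plain alkyl chain for another left the number where it was.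

Compound 4 `CN1C(=O)NC2(CC2c2ccc3cccc(OCc4ccccc4)c3n2)C1=O` has not been measured. The change is hydrogen in place of propyl on a saturated chain carbon bound to an amide-type nitrogen in a ring. For the measured compounds named here, no measured step replaces a chain with a hydrogen. The closest guide is no change at the digits printed from compound 1 to compound 3 (within the scatter), which is within the scatter, whereas a 10-fold lower number from compound 1 to compound 2 (1.00 log units; beyond the scatter) brings in a hydroxyl group that compound 4 lacks. On that basis the step of no change at the digits printed from compound 3 to compound 4 (within the scatter) is expected to stay within the scatter. Compound 4 is therefore estimated at 300 mg/kg in this assay, within a range from 100 mg/kg to 1000 mg/kg.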

Compound 4, minimum effective dose: 100 mg/kg
Compound 4: the middle estimate sits 3.0-fold (0.48 log units) above what was measured; the measured number falls inside the stated range.
By their numbers in this assay, from the lowest: compound 2; then compound 4; then compounds 1 and 3 (each within the scatter of the next).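

In this assay, a plain alkyl change at this position can move the number after all: with methyl in place of butyl or isopropyl, the results are a 3.0-fold lower number from compound 3 to compound 4 (0.48 log units; beyond the scatter) and a 3.0-fold lower number from compound 1 to compound 4 (0.48 log units; beyond the scatter), whereas the swap between butyl and isopropyl alone gave no sign of this. Methyl still does not match the 1-(hydroxymethyl)propyl group, with a 3.3-fold higher number from compound 2 to compound 4 (0.52 log units; beyond the scatter), so compound 2 keeps the lowest number of the four. No measurement shown here gives a reason for these steps.

The compounds shown leave open whether the hydroxyl group alone accounts for the low number of compound 2, or whether a shorter hydroxyethyl group would give a similar result. Also open, from the compounds shown here alone, is how an amine or a carboxylic acid on this nitrogen would read in this assay.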